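Pyridin-4-yl for 6-carbamoylpyridin-3-yl: notes on compound 4

The source may report more compounds than this note shows. Statements on the series, on what has been measured and on what is new or still open speak of the compounds shown alone.

Measured in a functional assay on A2058 cells (Homo sapiens) for antiproliferative activity, read by luminescence and CellTiter-Glo, with a stated time of 96 h; a lower number here means a stronger inhibitor, a higher number a weaker inhibitor:
- compound 1 `NC(=O)c1ccc(-c2ccc(F)c(C(=O)Nc3c[nH]nc3C(=O)Nc3ccc(F)cc3)c2F)cn1`: 295 nM
- compound 2 `NS(=O)(=O)c1ccc(Nc2nc(-c3cccc(-c4ccccc4)c3)c3nc[nH]c3n2)cc1`: > 100000 nM
- compound 3 `CN1CCC(CNC(=O)c2cccc(-c3ccc(F)c(C(=O)Nc4c[nH]nc4C(=O)Nc4ccc(F)cc4)c3F)c2)CC1`: 3340 nM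

Compound 1 holds the lowest number in this assay. Compound 3 reads 3340 nM, higher than compound 1 by more than the usual scatter. Compound 2 gives > 100000 nM, which is a limit of the assay and not a number.

The step under study leads to compound 4 `O=C(Nc1ccc(F)cc1)c1n[nH]cc1NC(=O)c1c(F)ccc(-c2ccncc2)c1F`, with pyridin-4-yl in place of 6-carbamoylpyridin-3-yl on an aromatic carbon. For the measured compounds named here, no measured pair isolates this change. Compound 1 at 295 nM and compound 3 at 3340 nM share the core and differ at this same place, so the group there can move the number. For this change, no shift beyond the scatter is expected in this assay, with a slight lean towards a higher number. The expected size is a 1.5-fold higher number from compound 1 to compound 4 (0.18 log units; within the scatter). Compound 4 is estimated at 450 nM, with an expected range of 100 nM to 2500 nM.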

Compound 4, half-maximal inhibitory concentration: 2940 nM
Compound 4: middle estimate off by 6.5-fold (0.82 log units), on the low side; the measured number lies above the stated range.
By their numbers in this assay, from the lowest: compound 1; then compounds 4 and 3 (each within the scatter of the next). At a limit, above all of these: compound 2.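

In this assay, for the compounds shown here, pyridin-4-yl in place of 6-carbamoylpyridin-3-yl gives a 10-fold higher number from compound 1 to compound 4 (1.00 log units; beyond the scatter) as the one step isolated at this position, so the group on this aromatic carbon matters even when the entering group keeps a six-membered aromatic ring with a hetero atom. Compound 3 at 3340 nM and compound 4 at 2940 nM lie within the scatter of each other, and among these three compounds only the 6-carbamoylpyridin-3-yl group of compound 1 goes with the lower number. Nothing shown here gives a cause for this step.

The step removes the carbamoyl group and also changes the ring attachment, and the compounds shown do not separate these two changes. Plain pyridin-3-yl would separate them, and a carboxylic acid or an aminomethyl group in place of the carbamoyl would show how specific that group is.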